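The compounds below may be only part of what the source reports. "The series", "measured", "known", "first", "only" and "open" are said of these compounds alone.

Series notes. Compound 1 `CCOC(=O)[C@@H]1CCCN(S(=O)(=O)c2ccc(S(=O)(=O)N(CC)C(C)C)cc2)C1` is the reference point for the step followed here. In a functional assay on MIA PaCa-2 cells (Homo sapiens) for inhibition, read by MTT assay, with a stated time of 3 days (on this read-out higher numbers stand for weaker inhibition and lower numbers for stronger inhibition), compound 1 returns only a limit of the assay, > 10000 nM, and no number. Two further members of the set give the same kind of result. Compound 2 `CCOC(=O)[C@@H]1CCN(S(=O)(=O)c2ccc(S(=O)(=O)N(CC)CC)cc2)C1` in this assay also returns a limit of the assay, > 10000 nM. Compound 3 `CCN(CC)S(=O)(=O)c1ccc(S(=O)(=O)N2CCC[C@@H](C(=O)N3CCC(c4nc(C(C)C)no4)CC3)C2)cc1` in this assay likewise returns a limit of the assay, > 10000 nM. Where compound 1 stands is therefore known only as a bound: every value measured so far sits at the limit of > 10000 nM in this assay, at which 3 of the 3 values shown sit. Within the data shown here, no two measured compounds differ in a single place, so no measured step is available to calibrate what a change at the sulfonyl sulfur does.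

The compound to be measured next is compound 4 `CCCN(CCC)S(=O)(=O)c1ccc(S(=O)(=O)N2CCC[C@@H](C(=O)OCC)C2)cc1`. It differs from compound 1 in one place: dipropylamino in place of ethyl(isopropyl)amino on a sulfonyl sulfur. Among the measured compounds shown here, with three of three values at the limit and no measured step, nothing in these data points to a gain of potency beyond the scatter. The step expected in this assay is a step that the limit leaves unreadable from compound 1 to compound 4, none beyond the scatter, and the most likely outcome is once more a limit rather than a number. Compound 4 is estimated in this assay at 15000 nM, with a range from 5000 nM to 50000 nM.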

Compound 4, half-maximal inhibitory concentration: > 10000 nM
Compound 4 was reported as a limit (the forecaster's own chance of this, stated with the estimate: 85%); the middle value does not contradict the limit.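

Compound 1 and compound 4 both return only a limit of the assay in this assay, so no step can be read for dipropylamino in place of ethyl(isopropyl)amino on a sulfonyl sulfur. The compounds shown leave open whether any member of this series gives a numerical potency, since all remain at one bound: the limit of > 10000 nM in this assay, at which 4 of the 4 values shown sit.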